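Methyl position on the pyridazinyl ring of the urea series

The source may report more compounds than this note shows. Statements on the series, on what has been measured and on what is new or still open speak of the compounds shown alone.

Compound 1 `Cc1ccc(N2CCN(C(=O)Nc3nc4ccc(F)cc4s3)CC2)nn1`: in an assay on HEK293 cells for inhibition of transient receptor potential cation channel subfamily V member 1 (Homo sapiens), read by FLIPR (a higher number here means a weaker inhibitor, a lower number a stronger inhibitor), compound 1 gives only a limit, > 10000 nM.
Compound 2 `O=C(Nc1nc2ccc(F)cc2s1)N1CCN(c2cccnn2)CC1`: in this assay compound 2 also gives only a limit, > 10000 nM.
Compound 3 `Cc1ccnnc1N1CCN(C(=O)Nc2nc3ccc(F)cc3s2)CC1`: in this assay compound 3 gives 6170 nM.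

Compound 3 holds the only number shown in this assay; the two other values sit at the limit of the assay (the limit of > 10000 nM in this assay, at which 2 of the 3 values shown sit). From compound 3 the series goes to compound 4 `Cc1cnnc(N2CCN(C(=O)Nc3nc4ccc(F)cc4s3)CC2)c1`, with 5-methylpyridazin-3-yl in place of 4-methylpyridazin-3-yl on an amine nitrogen in a ring.

Within the data shown here, two measured steps bear on this move. Shifting the methyl from the 6-position to the 4-position gives an at least 1.6-fold lower number from compound 1 to compound 3 (0.20 log units; that floor lies within the scatter), and adding the methyl at the 4-position gives an at least 1.6-fold lower number from compound 2 to compound 3 (0.20 log units; that floor lies within the scatter). Both floors lie within the scatter, so the methyl at the 4-position is only weakly better than hydrogen or than the 6-methyl. Nothing shown covers the 5-position. The 6-methyl compound 1 sits at the limit, so a methyl away from the 4-position is expected to give a number at or near the limit; for compound 4 the expected change is a 1.5-fold higher number from compound 3 to compound 4 (0.16 log units; within the scatter), weaker than compound 3 or no change beyond the scatter. The estimate for compound 4 in this assay is 9000 nM, with a range from 3000 nM to 30000 nM.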

Compound 4, half-maximal inhibitory concentration: > 10000 nM
Compound 4: no number, only a limit (the forecaster's own chance of this, stated with the estimate: 45%); at least 1.1-fold (0.04 log units) between middle value and limit.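

In this assay compound 4 gives only a limit, > 10000 nM. The change to 5-methylpyridazin-3-yl gives an at least 1.6-fold higher number from compound 3 to compound 4 (0.20 log units; that floor lies within the scatter); among the methylpyridazinyl groups shown, only the 4-methylpyridazin-3-yl of compound 3 gives a number. The steps to compound 4 from compound 1 and from compound 2 cannot be read, and the comparison of methyl placement still rests on a single number: the limit of > 10000 nM in this assay, at which 3 of the 4 values shown sit.

On these data alone, how far compound 4 lies past its limit stays open, and with it the true size of the step from compound 3. Also open, as far as these compounds go, is whether an ethyl or methoxy group in place of the methyl of 4-methylpyridazin-3-yl would bring a lower number than compound 3 gives.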